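Lengthening the nitrile chain: from compound 3 to compound 4

This account rests on a few compounds, and the source may have more. Where it says the series, first, only, none or still open, it means among the compounds named here.

Three compounds have been measured in an assay on isolated protein for binding affinity to leukotriene B4 receptor 1 (Homo sapiens), tested at 1 uM; a higher number here means more inhibition at the concentration tested (going by the name of the read-out), a lower number less inhibition:
compound 1, `CC(=O)c1cc(CC(C)O)c(OCCCCC#N)cc1O`, gives 6%
compound 2, `CC(=O)c1cc(C=O)c(OCCCCC#N)cc1O`, gives 3%
compound 3, `C=CCc1cc(C(C)=O)c(O)cc1OCCCC#N`, gives 6%

Compound 3 stands level with compound 1 at the digits shown, and the two together are the highest of the three numbers; compound 2 is the furthest from compound 3, but that distance is within the usual scatter. Going by the values given here, the only change between measured compounds that differs in one place is a number 3 percentage points lower from compound 1 to compound 2 (within the scatter), with formyl in place of 2-hydroxypropyl on an aromatic carbon, a step within the scatter and one that concerns a different part of the molecule.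

Compound 4, `C=CCc1cc(C(C)=O)c(O)cc1OCCCCCCCCC#N`, is the next compound to be measured in this assay. It differs from compound 3 in one place: 5-cyanopentyl in place of cyano on a saturated chain carbon, three bonds along the chain from an oxygen on an aromatic ring. Among the compounds with values here, no measured step touches the length of this chain, so nothing among the three numbers points to a change in either direction, and all three numbers sit low and close together.

Compound 4 is therefore expected to give about 7% in this assay, with a range from 0% to 20%. This estimate means a step of a number 1 percentage points higher from compound 3 to compound 4 (within the scatter), which is expected to stay within the scatter.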

Compound 4, a percentage reported as inhibition, at one concentration (the size of the read-out at that concentration, not a potency): 50%
The estimate for compound 4 lay 43 percentage points below the measured number; measured number above the stated range.
By their numbers in this assay, from the lowest: compounds 2, 1 and 3 (each within the scatter of the next); then compound 4.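

In this assay, putting 5-cyanopentyl in place of cyano, on a saturated chain carbon, three bonds along the chain from an oxygen on an aromatic ring, gives a number 44 percentage points higher from compound 3 to compound 4 (beyond the scatter). Going by these compounds alone, this is the first single change to move the number beyond the scatter, so the read-out is sensitive to the length of this nitrile-bearing chain in a way that the one earlier step, made at a different place in the molecule, gave no sign of. Nothing available explains why the added chain carbons have this effect, and a single-concentration read-out gives no potency.

Two chain lengths cannot show whether the number climbs steadily, jumps at some particular length or would fall again with a still longer chain. Going by these compounds, it also remains open whether the nitrile at the chain end matters or the chain alone is enough, a question that a plain alkyl chain, or a chain ending in a carboxylic acid or an amine, would address.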